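The compounds below may be only part of what the source reports. "The series", "measured", "known", "first", "only" and "open" are said of these compounds alone.

Measured so far:
- compound 1, `CCc1cc2ccccc2nc1-c1cc(-c2ccc(C)cc2)no1`: > 100000 nM
- compound 2, `CCCc1cc2ccccc2nc1-c1cc(-c2ccc(C)cc2)no1`: > 100000 nM
- compound 3, `CCCCc1cc2ccccc2nc1-c1cc(-c2ccc(C(F)(F)F)cc2)no1`: 9400 nM

All three were tested in a functional assay on A549 cells (Homo sapiens) for inhibition, read by MTT assay, with a stated time of 24 h; a lower number here means a stronger inhibitor, a higher number a weaker inhibitor. Compound 1 gives only a limit in this assay, > 100000 nM, and no number. Compound 2 likewise gives only a limit, > 100000 nM. Among the measured compounds shown here, compound 3 is the single compound with a number, 9400 nM. The change from compound 1 to compound 2 is methyl in place of hydrogen on a saturated chain carbon, two bonds along the chain from an aromatic carbon; the step it made, a step that the two limits leave unreadable from compound 1 to compound 2, cannot be read, because the limit of > 100000 nM in this assay, at which 2 of the 3 values shown sit, hides both ends of it.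

Compound 3 differs from compound 1 in more than one place, and the difference between the two cores is not broken down here; only the two values can be set side by side, one a limit and one a number.

The unmeasured compound is compound 4, `CCCCCc1cc2ccccc2nc1-c1cc(-c2ccc(C(F)(F)F)cc2)no1`. It differs from compound 3 by methyl in place of hydrogen on a saturated chain carbon, four bonds along the chain from an aromatic carbon. For the measured compounds named here, this is the same kind of change as the one from compound 1 to compound 2, but not the same: there the methyl enters two bonds along the chain from an aromatic carbon, here four bonds along the chain from an aromatic carbon. Going by the values given here, since the measured step of this kind could not be read, the only anchor for compound 4 is the number of compound 3, 9400 nM. Compound 4 is therefore expected to sit close to that anchor, with the step of a 1.2-fold lower number from compound 3 to compound 4 (0.07 log units; within the scatter) estimated to stay within the usual scatter. The estimate for compound 4 in this assay is 8000 nM, with a range from 3000 nM to 25000 nM.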

Compound 4, half-maximal inhibitory concentration: 28300 nM
Beside the measured number, compound 4's estimate is 3.5-fold (0.55 log units) below it, and the stated range ends below it.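

In this assay, methyl in place of hydrogen on a saturated chain carbon, four bonds along the chain from an aromatic carbon, gives a 3.0-fold higher number from compound 3 to compound 4 (0.48 log units; beyond the scatter), a modest step that lies beyond the usual scatter and points to a weaker inhibitor on this core. The same kind of change on the core of compound 1, made two bonds along the chain from an aromatic carbon, cannot be read, because neither of its two compounds gives a number, only a limit: the limit of > 100000 nM in this assay, at which 2 of the 4 values shown sit. The series therefore offers one readable step of this kind, on one core and at one place on the chain, and it does not show whether the change would carry the same size or direction from one core to the other.

The compounds shown leave open how the number would move with a longer chain on the core of compound 4, and whether a further step of this kind would go the same way as this one. Also open, from the compounds shown here alone, is what an amine or a carboxylic acid in place of that chain would do in this assay, and whether any chain on the core of compound 1 would give a number rather than a limit.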